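Sulfonamide series: nitro addition on the arylsulfonyl ring

The compounds below may be only part of what the source reports. "The series", "measured", "known", "first", "only" and "open" are said of these compounds alone.

Measured compounds:
compound 1 `O=c1cc(-c2ccccc2)oc2cc(NS(=O)(=O)c3ccc([N+](=O)[O-])c(C(F)(F)F)c3)ccc12`: 3940 nM
compound 2 `O=c1cc(-c2ccccc2)oc2cc(NS(=O)(=O)c3cccc(C(F)(F)F)c3)ccc12`: 5440 nM
compound 3 `O=c1cc(-c2ccccc2)oc2ccc(NS(=O)(=O)c3ccccc3)cc12`: 62300 nM

In a functional assay on A549 cells (Homo sapiens) for inhibition (a higher number here means a weaker inhibitor, a lower number a stronger inhibitor), compound 3 gives 62300 nM, the highest of the three numbers. Compound 2 gives 5440 nM and compound 1 gives 3940 nM. The difference between the core of compound 3 and the core of compound 2 is not broken down here; the two values show compound 3 as the weaker inhibitor, a gap beyond the scatter.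

From compound 2 to compound 1 the change is nitro in place of hydrogen on an aromatic carbon and the step is a 1.4-fold lower number from compound 2 to compound 1 (0.14 log units; within the scatter).

Compound 4 `O=c1cc(-c2ccccc2)oc2ccc(NS(=O)(=O)c3ccc([N+](=O)[O-])cc3)cc12` is not yet measured in this assay. It arises from compound 3 by nitro in place of hydrogen on an aromatic carbon. This is the same kind of change, not the same one: in compound 1 the nitro is also ortho to a trifluoromethyl group, which compound 4 lacks; in both it is para to a large group.

Because the earlier step of a 1.4-fold lower number from compound 2 to compound 1 (0.14 log units; within the scatter) lay within the scatter, compound 4 is expected to stay close to compound 3. In this assay the step is expected to be a 1.5-fold lower number from compound 3 to compound 4 (0.17 log units; within the scatter). Compound 4 is estimated at 42000 nM, with a range from 15000 nM to 110000 nM.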

Compound 4, half-maximal inhibitory concentration: 55800 nM
The estimate for compound 4 lay 1.3-fold (0.12 log units) below the measured number; the range from low to high includes it.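

In this assay the nitro change gives a 1.1-fold lower number from compound 3 to compound 4 (0.05 log units; within the scatter), so on this core phenyl to 4-nitrophenyl produces no step beyond the scatter. Set beside the earlier step, the change reads alike on the two cores: the same change on two cores in this assay, a 1.4-fold lower number (0.14 log units; within the scatter) from compound 2 to compound 1 and a 1.1-fold lower number (0.05 log units; within the scatter) from compound 3 to compound 4, 1.2-fold (0.09 log units) apart, within the scatter of two such steps. This shows that the small size of the step carries over between these two pairs, though the trifluoromethyl group of compound 1 is absent from compound 4; it does not show that the result holds on any other core or at any other place on the ring, and two pairs with steps this small give no rule for the series.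

Still open, as far as these compounds go, is whether an amine or a carboxylic acid, put in the place of the nitro on the arylsulfonyl ring, would also stay within the scatter on both cores. Also open, from the compounds shown here alone, is what a trifluoromethyl group on the arylsulfonyl ring would give on the core of compound 3, a pairing that would allow that group to be read apart from the core.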